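Shifting a Halogen Around the Pendant Phenyl Ring

The compounds below may be only part of what the source reports. "The series", "measured", "known", "first", "only" and "open" are said of these compounds alone.

Compound 2 `CC1(C)[C@H]2CC[C@]1(C)N(Cc1cn(-c3ccc(C#N)cc3)nn1)C(=O)C2` gives 380 nM in a functional assay on OVCAR-3 cells (Homo sapiens) for inhibition, read by MTT assay, with a stated time of 24 h (a higher number here means a weaker inhibitor, a lower number a stronger inhibitor), the highest number of the three measured compounds; compound 1 `CC1(C)[C@H]2CC[C@]1(C)N(Cc1cn(-c3ccccc3Br)nn1)C(=O)C2` gives 140 nM and compound 3 `CC1(C)[C@H]2CC[C@]1(C)N(Cc1cn(-c3ccccc3C#N)nn1)C(=O)C2` gives 110 nM. Compound 4 `CC1(C)[C@H]2CC[C@]1(C)N(Cc1cn(-c3cccc(Br)c3)nn1)C(=O)C2` differs from compound 2 by 3-bromophenyl in place of 4-cyanophenyl on an aromatic nitrogen. Within the data shown here, two measured steps bear on this change: a 3.5-fold lower number from compound 2 to compound 3 (0.54 log units; beyond the scatter), and a 1.3-fold lower number from compound 1 to compound 3 (0.10 log units; within the scatter). The first shows that the place of the group on the phenyl ring makes a modest difference; the second shows that bromo and cyano give similar numbers when they share a place. Among the measured compounds shown here, a modest downward step is therefore expected, a 1.9-fold lower number from compound 2 to compound 4 (0.28 log units; within the scatter), though no measured compound carries 3-bromophenyl, so the estimate is uncertain. Compound 4 is estimated at 200 nM, within a range of 90 nM to 450 nM.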

Compound 4, half-maximal inhibitory concentration: 30 nM
Beside the measured number, compound 4's estimate is 6.7-fold (0.82 log units) above it; measured number outside the range, below it.
By their numbers in this assay, from the lowest: compound 4; then compounds 3 and 1 (each within the scatter of the next); then compound 2.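

Among these compounds, the place of bromo on the phenyl ring matters more than the earlier compounds showed: in this assay there is a 4.7-fold lower number from compound 1 to compound 4 (0.67 log units; beyond the scatter) with only that place changed. 3-Bromophenyl also outdoes the better nitrile, with a 3.7-fold lower number from compound 3 to compound 4 (0.56 log units; beyond the scatter) and, against 4-cyanophenyl, a 13-fold lower number from compound 2 to compound 4 (1.10 log units; beyond the scatter) as the largest step here. No measurement available explains this preference.

Still open, as far as these compounds go, is whether the gain belongs to this place or to bromo itself, which a 3-cyanophenyl ring would separate. An amine or a carboxylic acid on the same ring would show how widely the group can vary.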